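Chalcone-type series: inhibition of HOP-92 cell growth

The source may hold more compounds than are shown below. What is called first, only, known or untested is meant among the compounds shown, and "the series" means these compounds.

Measured so far:
- compound 1, `COc1cc(/C=C/C(=O)c2cccc(-n3cc(-c4ccc(Cl)cc4)[nH]c3=O)c2)cc(OC)c1OC`: "not active" (no number reported) in a functional assay on HOP-92 cells (Homo sapiens) for inhibition; on this read-out higher numbers stand for weaker inhibition of growth and lower numbers for stronger inhibition of growth
- compound 2, `COc1cc(/C=C/C(=O)c2cccc(-n3cc(-c4ccccc4)[nH]c3=O)c2)cc(OC)c1OC`: 10800 nM
- compound 3, `COc1ccc(-c2cn(-c3cccc(C(=O)/C=C/c4ccc(O)c(OC)c4)c3)c(=O)[nH]2)cc1`: 2960 nM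

Compound 3 has the lowest of the two numbers in this assay; compound 2 gives a higher number, and the gap between compound 3 and compound 2 is beyond the scatter. Compound 1 was reported without a number.

Compound 4, `COc1ccc(-c2cn(-c3cccc(C(=O)/C=C/c4cc(OC)c(OC)c(OC)c4)c3)c(=O)[nH]2)cc1`, differs from compound 3 by 3,4,5-trimethoxyphenyl in place of 4-hydroxy-3-methoxyphenyl on a double-bonded chain carbon bound to a double-bonded chain carbon. Compound 4 shares its trimethoxyphenyl-bearing chain with compound 2 and compound 1, both of which gave weaker results than compound 3. From the compounds shown here alone, a step toward weaker inhibition beyond the scatter is therefore expected, though the pairing with the 4-methoxyphenyl group on the core is untested. For compound 4 the expected step is a 2.5-fold higher number from compound 3 to compound 4 (0.40 log units; beyond the scatter). Compound 4 is estimated at 7500 nM, with a range from 2500 nM to 22000 nM.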

Compound 4, concentration for 50% growth inhibition: 14900 nM
Estimate against measurement, compound 4: 2.0-fold (0.30 log units) below; measured number inside the range.
By their numbers in this assay, from the lowest: compound 3; then compounds 2 and 4 (each within the scatter of the next).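

In this assay, 3,4,5-trimethoxyphenyl in place of 4-hydroxy-3-methoxyphenyl on a double-bonded chain carbon bound to a double-bonded chain carbon gives a 5.0-fold higher number from compound 3 to compound 4 (0.70 log units; beyond the scatter) and shows that this position responds to the change with the rest of compound 3 held fixed. Methoxy in place of hydrogen on an aromatic carbon gives a 1.4-fold higher number from compound 2 to compound 4 (0.14 log units; within the scatter) and so resolves no difference with the trimethoxyphenyl chain held fixed. Nothing available explains either step.

From the compounds shown here alone, the first step swaps the whole aryl group, so the part of it that counts stays open. Also open, going by these compounds, is how an amine or a carboxylic acid in place of the hydroxy group would read.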